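The source may hold more compounds than are shown below. What is called first, only, known or untested is meant among the compounds shown, and "the series" means these compounds.

Compound 1 `c1ccc(C2CC3(N4CCCCC4)CCN(CCCN4CCCCC4)C2C(c2ccccc2)C3)cc1` was tested in an ADME assay on L6 cells (Rattus norvegicus) for cytotoxicity (on this read-out higher numbers stand for weaker inhibition and lower numbers for stronger inhibition), where compound 1 gives 138000 nM. Among the measured compounds shown here, the only other measured compound, compound 2 `CN(C)C12CC(NCN3CCCC3)C(C(c3ccccc3)C1)C(c1ccccc1)C2`, gives 69300 nM in this assay; the two numbers lie within the usual scatter of each other, so they show no difference between these two compounds. Compound 3 `O=C(CCN1CCCCC1)N1CCC2(N3CCCCC3)CC(c3ccccc3)C1C(c1ccccc1)C2` has not yet been measured. It differs from compound 1 by a single change: (2-(piperidin-1-yl)ethyl)carbonyl in place of 3-(piperidin-1-yl)propyl on an amine nitrogen in a ring. No measured step like this exists among these compounds, so the step from compound 1 to compound 3 is expected to stay within the scatter, as a 1.2-fold lower number from compound 1 to compound 3 (0.06 log units; within the scatter). For compound 3 the expected result in this assay is 120000 nM, in a range of 50000 nM to 300000 nM.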

Compound 3, half-maximal inhibitory concentration: 63900 nM
Beside the measured number, compound 3's estimate is 1.9-fold (0.27 log units) above it; the measured number falls inside the stated range.
By their numbers in this assay, from the lowest: compounds 3, 2 and 1 (each within the scatter of the next, the first and the last beyond it).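

In this assay, the amine nitrogen in the seven-membered ring proves to be a place where a change can move the read-out: replacing 3-(piperidin-1-yl)propyl with (2-(piperidin-1-yl)ethyl)carbonyl gives a 2.2-fold lower number from compound 1 to compound 3 (0.33 log units; beyond the scatter). Among the compounds shown here, this modest step toward stronger inhibition is the first one measured at this nitrogen. No available evidence gives a reason for it. The compounds shown leave open whether the carbonyl or some other part of the swap accounts for the step. They also leave open how a plain acetyl group or a chain ending in morpholine would behave on this nitrogen.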